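A few compounds are considered here, and "the series" means these few. Any claim that something is new, unique, unknown or untested is made for them only; others in the source may bear on it.

Compound 1 `CCNC(=O)Nc1ccc(-c2nc3n(Cc4c(F)cccc4F)cc(C(=O)NCc4cn(CCOCCN=[N+]=[N-])nn4)c(=O)n3c2CN(C)Cc2ccccc2)cc1` — in a functional assay on CHO cells for antagonist activity at Gonadotropin-releasing hormone receptor (Homo sapiens), read by a luciferase reporter, with a stated time of 30 min (a lower number here means a stronger inhibitor, a higher number a weaker inhibitor), compound 1 gives < 10000 nM, a limit of the assay and not a number.
Compound 2 `CCNC(=O)Nc1ccc(-c2nc3n(Cc4c(F)cccc4F)cc(C(=O)NCc4cn(CCOCCOCCN=[N+]=[N-])nn4)c(=O)n3c2CN(C)Cc2ccccc2)cc1` — in this assay compound 2 gives < 10000 nM, again a limit.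
Compound 3 `CCNC(=O)Nc1ccc(-c2nc3n(Cc4c(F)cccc4F)cc(C(=O)NCc4cn(CCOCCOCCOCCN=[N+]=[N-])nn4)c(=O)n3c2CN(C)Cc2ccccc2)cc1` — in this assay compound 3 gives < 10000 nM, also a limit.

Compound 3 therefore stands only on a limit, and the two other values shown are limits as well (the limit of < 10000 nM in this assay, at which 3 of the 3 values shown sit). The measured steps between them, a step that the two limits leave unreadable from compound 1 to compound 2, a step that the two limits leave unreadable from compound 1 to compound 3 and a step that the two limits leave unreadable from compound 2 to compound 3, cannot be read in size or direction from two limits.

Compound 4 `CCNC(=O)Nc1ccc(-c2nc3n(Cc4c(F)cccc4F)cc(C(=O)NCc4cn(CCN=[N+]=[N-])nn4)c(=O)n3c2CN(C)Cc2ccccc2)cc1` differs from compound 3 by azido in place of 2-(2-(2-azidoethoxy)ethoxy)ethoxy on a saturated chain carbon, two bonds along the chain from an aromatic nitrogen. Among the compounds with values here, the steps that bear on this change are those that lengthen or shorten the same chain, and all three are unreadable, so no direction beyond the scatter can be claimed for the step from compound 3 to compound 4 in this assay. Because the three values sit at the limit (the limit of < 10000 nM in this assay, at which 3 of the 3 values shown sit), the expectation for compound 4 is that it also lands there, and the estimated step that the limit leaves unreadable from compound 3 to compound 4 is taken as none. Compound 4 is estimated at 300 nM, within 10 nM to 9000 nM.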

Compound 4, half-maximal inhibitory concentration: < 10000 nM
Compound 4: no number, only a limit (the forecaster's own chance of this, stated with the estimate: 70%); the middle value does not contradict the limit.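

Compound 4 adds no readable step: its comparisons with compound 1, compound 2 and compound 3 in this assay all join two limits, so neither size nor direction can be read: the limit of < 10000 nM in this assay, at which 4 of the 4 values shown sit.

The compounds shown leave open how strongly any of them actually inhibits, and whether chain length matters at all.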